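The source may hold more compounds than are shown below. What is called first, only, known or untested is meant among the compounds shown, and "the series" means these compounds.

Three compounds measured in an ADME assay on MDCK-II cells (Canis lupus familiaris) for inhibition, read by MTT assay, with a stated time of 72 h (a lower number here means a stronger inhibitor of growth, a higher number a weaker inhibitor of growth), so far:

- compound 1 `COc1cccc(/C=C/C(=O)c2ccc(OCC(=O)Nc3ccc(OC)c(OC)c3)cc2)c1`: 33200 nM
- compound 2 `O=C(COc1c(-c2ccccc2Cl)oc2ccccc2c1=O)Nc1ccc2c(c1)COC2=O`: 67600 nM
- compound 3 `COc1ccc(-c2c(OCC(=O)Nc3cccc4ccccc34)oc3ccccc3c2=O)cc1`: > 100000 nM (a limit, not a number)

Compound 1, at 33200 nM, has the lower of the two actual numbers, and its gap to compound 2 lies just beyond the usual scatter of repeat measurements. Compound 3 reached only a limit, so it cannot be placed exactly.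

Compound 4 `COc1ccc(NC(=O)COc2ccc(C(=O)/C=C/c3cc(OC)c(OC)c(OC)c3)cc2)cc1OC` is still unmeasured. It keeps the rest of compound 1 but carries 3,4,5-trimethoxyphenyl in place of 3-methoxyphenyl on a double-bonded chain carbon bound to a double-bonded chain carbon.

For the measured compounds named here, no measured pair of compounds shows what this change does in this assay, so any forecast is uncertain. A modest move towards a lower number seems most likely, and a change no larger than the scatter remains quite possible. The expected change is a 1.5-fold lower number from compound 1 to compound 4 (0.18 log units; within the scatter) as an estimate. For compound 4 the estimated value is 22000 nM, with an expected range from 6000 nM to 80000 nM.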

Compound 4, concentration for 50% growth inhibition: 18900 nM
Estimate against measurement, compound 4: 1.2-fold (0.07 log units) above, and the stated range covers the measured number.
By their numbers in this assay, from the lowest: compounds 4 and 1 (each within the scatter of the next); then compound 2. At a limit, above all of these: compound 3.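

For the compounds shown here, compound 1 and compound 4 differ in one place only, so they give the first direct reading of a change on a double-bonded chain carbon bound to a double-bonded chain carbon: in this assay, 3,4,5-trimethoxyphenyl in place of 3-methoxyphenyl gives a 1.8-fold lower number from compound 1 to compound 4 (0.24 log units; within the scatter). The larger group, with its extra methoxy groups, therefore leaves the two compounds indistinguishable in this assay, and the added bulk carries no measurable penalty or clear gain here. Going by these compounds alone, nothing measured so far accounts for this result.

From the compounds shown here alone, it remains open whether a different kind of group at this place, such as a plain phenyl, a pyridine ring or a phenyl carrying an amine or a carboxylic acid, would move the number beyond the scatter. Compound 2 and compound 3 differ from compound 1 in more than one place, so no further steps can be read from them.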